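A Change of Aryl Group: From Compound 2 to Compound 3

The source may hold more compounds than are shown below. What is called first, only, known or untested is meant among the compounds shown, and "the series" means these compounds.

Two compounds have been examined in a functional assay on MDA-MB-231 cells (Homo sapiens), read by fluorescence and BrdU incorporation, with a stated time of 48 h, tested at 10 uM; on this read-out lower numbers stand for a stronger effect and higher numbers for a weaker effect at the one concentration tested. Compound 1 `COc1cc(O)c(C(=O)/C=C/c2ccc(F)cc2)c(OC)c1` is recorded in this assay as "not active" (no number reported), so no number stands for it. Compound 2 `COc1cc(OC)c(C(=O)/C=C/c2ccccc2SC)c(OC)c1` gives 48% in this assay. This is the only number shown; compound 1 carries a note rather than a number, so the two compounds cannot be set against each other as a step, and compound 2 stands alone as the sole reference point.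

Compound 3 `COc1cccc(/C=C/C(=O)c2c(OC)cc(OC)cc2OC)c1` has not yet been measured in this assay. It differs from compound 2 in one place: 3-methoxyphenyl in place of 2-(methylsulfanyl)phenyl on a double-bonded chain carbon bound to a double-bonded chain carbon. For the measured compounds named here, no measured pair shows this change, so there is no step to lean on, and the expectation rests on compound 2 alone.

The step is expected to be small, a number 7 percentage points higher from compound 2 to compound 3 (within the scatter), not clearly beyond the scatter in either direction. Compound 3 is estimated at 55%, with a range from 30% to 85%.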

Compound 3, a percentage reported as activity, at one concentration (the size of the read-out at that concentration, not a potency): 43%
For compound 3 the middle estimate is 12 percentage points above the measured one; measured number inside the range.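

In this assay, for the compounds shown here, the change of aryl group gives a number 5 percentage points lower from compound 2 to compound 3 (within the scatter), the first step that can be read at this position. It shows that this exchange of one substituted phenyl group for another, with an oxygen-bearing group entering and a sulfur-bearing group leaving, does not move the read-out beyond the scatter at the one concentration tested. No measurement at hand offers an explanation for this outcome.

The two groups differ both in their substituent and in where it sits on the phenyl ring, so the compounds shown do not separate these two changes. As far as these compounds go, how an amine or a carboxylic acid on this phenyl ring would read in this assay also remains open.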